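Two chlorines added to the sulfophenyl of compound 3

The source may hold more compounds than are shown below. What is called first, only, known or untested is meant among the compounds shown, and "the series" means these compounds.

Three compounds share one core: compound 1 `Cc1[nH]n(-c2cccc(C(F)(F)F)c2)c(=O)c1/N=N/c1c(O)cc(S(=O)(=O)O)c2ccccc12`, compound 2 `Cc1[nH]n(-c2ccc(C(=O)O)cc2)c(=O)c1/N=N/c1c(O)cc(S(=O)(=O)O)c2ccccc12` and compound 3 `Cc1[nH]n(-c2ccc(S(=O)(=O)O)cc2)c(=O)c1/N=N/c1c(O)cc(S(=O)(=O)O)c2ccccc12`. In an assay on BaF3 cells with thrombopoietin receptor (Homo sapiens) as the target, read by a luciferase reporter (on this read-out lower numbers stand for smaller maximal responses and higher numbers for larger maximal responses), compound 1 gives 62%. Compound 2 reaches only the assay's limit of < 5%. Compound 3 also sits at a limit, < 5%, so no number is known for it. The steps of a number at least 57 percentage points lower from compound 1 to compound 2 (beyond the scatter) and a number at least 57 percentage points lower from compound 1 to compound 3 (beyond the scatter) are both large, whereas a step that the two limits leave unreadable from compound 2 to compound 3 cannot be read because both values sit at the limit of < 5% in this assay, at which 2 of the 3 values shown sit. Compound 4 `Cc1[nH]n(-c2cc(Cl)c(S(=O)(=O)O)cc2Cl)c(=O)c1/N=N/c1c(O)cc(S(=O)(=O)O)c2ccccc12` differs from compound 3 by a group of 12 heavy atoms (6 carbon, 3 oxygen, 1 sulfur, 2 chlorine; one six-membered aromatic ring of carbon only) in place of a group of 10 heavy atoms (6 carbon, 3 oxygen, 1 sulfur; one six-membered aromatic ring of carbon only), on an aromatic nitrogen. The sulfophenyl group that accompanied the fall to the limit remains, so compound 4 is expected to stay near that limit, at 5%, between 0% and 20%. The expected step of a number no lower from compound 3 to compound 4 (the limit leaves the size open) therefore lies within the scatter.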

Compound 4, largest response reached (reported as efficacy), in percent of the reference or control that the assay uses: < 5%
Compound 4 gave a limit, no number; the forecaster's own chance of this, stated with the estimate: 70%; the middle value lies on the limit itself.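

In this assay compound 4 gives only a limit, < 5%, and not a number. On this aromatic nitrogen the result is a number at least 57 percentage points lower from compound 1 to compound 4 (beyond the scatter), so a sulfophenyl ring carrying two chlorines does not bring back the response seen with 3-(trifluoromethyl)phenyl. The steps among compounds 2, 3 and 4 cannot be read because all three values sit at one limit: the limit of < 5% in this assay, at which 3 of the 4 values shown sit.

Going by these compounds, it remains open whether the sulfo group itself goes with the loss of response. A ring with the two chlorines but an amine or a methyl ester in place of the sulfo group would test this.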